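The source may hold more compounds than are shown below. What is called first, only, known or untested is meant among the compounds shown, and "the series" means these compounds.

Compound 1 `COc1ccc(Nc2ccc3ccccc3n2)cc1`: 51000 nM
Compound 2 `Cc1ccc(-c2ccnc(Nc3ccc(F)cc3)c2)cc1`: 146000 nM
Compound 3 `COc1ccc(Nc2cc(-c3cccc(C(F)(F)F)c3)ccn2)cc1`: 140000 nM

All three values come from a functional assay on HeLa cells (Homo sapiens) for cytotoxicity, read by MTT assay, with a stated time of 72 h; a lower number here means a stronger inhibitor, a higher number a weaker inhibitor. Compound 3 and compound 2 lie within the usual scatter of each other, so these two numbers cannot be told apart. Compound 1 has a lower number than compound 3, and that gap lies beyond the scatter. Compound 3 therefore stands level with compound 2, and both sit on the high-number side of this small set.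

The next compound is compound 4 `CCc1ccc(Nc2cc(-c3cccc(C(F)(F)F)c3)ccn2)cc1`, which has ethyl in place of methoxy on an aromatic carbon. The rest of the structure is unchanged. Among the measured compounds shown here, no two measured compounds differ in only one place, so the data give no direct measure of what a change like this does. The best starting point is compound 3 at 140000 nM, the closest measured relative.

In this assay, no change beyond the scatter is expected, with at most a slight shift towards a lower number. The expected step is a 1.3-fold lower number from compound 3 to compound 4 (0.10 log units; within the scatter). For compound 4 the estimated value is 110000 nM, with an expected range of 45000 nM to 220000 nM.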

Compound 4, half-maximal inhibitory concentration: > 200000 nM
Compound 4 gave a limit, no number (the forecaster's own chance of this, stated with the estimate: 15%); middle value at least 1.8-fold (0.25 log units) away from the limit.
By their numbers in this assay, from the lowest: compound 1; then compounds 3 and 2 (each within the scatter of the next). At a limit, above all of these: compound 4.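

Among the compounds shown here, compound 3 and compound 4 form the first pair in this set that differs in only one place, so the change from 4-methoxyphenyl to 4-ethylphenyl can now be read directly in this assay. Compound 4 gives > 200000 nM, which is a limit of the assay and not a number. The step is therefore known only as a floor, an at least 1.4-fold higher number from compound 3 to compound 4 (0.15 log units; that floor lies within the scatter); it shows that ethyl in place of methoxy brought no shift towards a lower number, but it does not establish a real change, and the true size of the step stays unknown: the limit of > 200000 nM in this assay, at which 1 of the 4 values shown sits.

Still open, as far as these compounds go, is whether any other group at this position, such as an amine, a carboxylic acid or a chain longer than ethyl, would move the number in either direction. A hydroxyl group or a plain hydrogen there could help show whether the methoxy oxygen itself matters, and this single pair cannot say whether the same change would behave alike on the core of compound 1.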